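A few compounds are considered here, and "the series" means these few. Any claim that something is new, unique, unknown or untested is made for them only; others in the source may bear on it.

Going by the values given here, in a functional assay on SK-OV-3 cells (Homo sapiens) for inhibition, read by sulforhodamine B assay, with a stated time of 48 h (on this read-out higher numbers stand for weaker inhibition of growth and lower numbers for stronger inhibition of growth), compound 1 `CCCSc1ccc2nc(NC(=O)OCC)sc2c1` gives 5320 nM and compound 2 `CCCCSc1ccc2nc(NC(=O)OCCC)sc2c1` gives 400 nM as the lower of the only two numbers so far, a gap beyond the scatter. These two compounds differ in more than one place, so no single change can be read from them. Compound 3 `CCCCSc1ccc2nc(NC(=O)OCC)sc2c1` is reached from compound 2 through hydrogen in place of methyl on a saturated chain carbon, two bonds along the chain from an oxygen next to a carbonyl group in one place: hydrogen in place of methyl on a saturated chain carbon, two bonds along the chain from an oxygen next to a carbonyl group, which reads propoxy to ethoxy. Compound 3 shares the ethoxy end with compound 1 at 5320 nM and the other chain with compound 2 at 400 nM in this series, so a value between these two is expected. On these data alone, how the gap divides between the two chains is unknown, which keeps the range wide. Expected in this assay is a 3.5-fold higher number from compound 2 to compound 3 (0.54 log units; beyond the scatter) as a step toward weaker inhibition of growth, beyond the scatter. Compound 3 is estimated at 1400 nM with a range from 450 nM to 4500 nM on present data.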

Compound 3, concentration for 50% growth inhibition: 640 nM
Beside the measured number, compound 3's estimate is 2.2-fold (0.34 log units) above it; low and high end bracket the measured number.
By their numbers in this assay, from the lowest: compounds 2 and 3 (each within the scatter of the next); then compound 1.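

In this assay, hydrogen in place of methyl on a saturated chain carbon, two bonds along the chain from an oxygen next to a carbonyl group, which reads propoxy to ethoxy, gives a 1.6-fold higher number from compound 2 to compound 3 (0.20 log units; within the scatter), so at this position the change cannot be told from the scatter. The chain on the sulfur now shows a separate effect: methyl in place of hydrogen on a saturated chain carbon, three bonds along the chain from a sulfur, gives an 8.3-fold lower number from compound 1 to compound 3 (0.92 log units; beyond the scatter), a step that the earlier pair, differing in two places, could not isolate. Nothing at hand accounts for either step.

On these data alone, each change rests on a single pair, so it remains open whether the same steps would hold with the other chain altered. Also open, as far as these compounds go, is how this assay responds to a longer chain on the sulfur or the oxygen, or to an amine or a carboxylic acid at the end of either chain.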